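The source may hold more compounds than are shown below. What is called first, only, known or untested is meant among the compounds shown, and "the series" means these compounds.

Measured so far in a functional assay on T47D cells (Homo sapiens) for cytotoxicity, read by colorimetric assay and MTT assay; a higher number here means a weaker inhibitor, a lower number a stronger inhibitor:

compound 1 `COc1ccc2cc(-c3ccccc3)c(O)nc2c1` gives 10000 nM
compound 2 `CCN(CC)C(=O)Cn1c(=O)c(-c2ccc(OC)cc2)cc2c(OC)cc(OC)cc21` gives 10000 nM

Compound 2 stands level with compound 1 on these numbers, and the two values lie within the scatter of each other. The two compounds do not form a step that differs in one place, so the data hold no measured guide to the size of a single change.

Compound 3 `CCN(CC)C(=O)CCn1c(=O)c(-c2ccc(OC)cc2)cc2c(OC)cc(OC)cc21` keeps the core of compound 2 and alters only the chain on the aromatic nitrogen, as counted here: (diethylcarbamoyl)methyl in place of diethylcarbamoyl on a saturated chain carbon bound to an aromatic nitrogen. This places (diethylcarbamoyl)methyl in place of diethylcarbamoyl on a saturated chain carbon bound to an aromatic nitrogen. Cut one bond further out, the change reads (diethylcarbamoyl)methyl to 2-(diethylcarbamoyl)ethyl.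

No step beyond the scatter is expected in this assay, and neither direction is favoured. This expectation rests on compound 2 at 10000 nM as the closest measured neighbour. The estimated step is no change at the digits printed from compound 2 to compound 3 (within the scatter), which would stay within the scatter. For compound 3 the estimated value is 10000 nM, with an expected range from 4000 nM to 20000 nM.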

Compound 3, half-maximal inhibitory concentration: 10000 nM
The estimate for compound 3 equals the measured number at the digits printed; the measured number falls inside the stated range.
By their numbers in this assay, from the lowest: compounds 1, 2 and 3 (each within the scatter of the next).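

In this assay, the chain on the aromatic nitrogen was the only thing that differed, with (diethylcarbamoyl)methyl in place of diethylcarbamoyl on a saturated chain carbon bound to an aromatic nitrogen, and the result was no change at the digits printed from compound 2 to compound 3 (within the scatter). Going by these compounds alone, this is the only step here that differs in one place, and so it gives the first measured guide to a single change at this position: read one bond further out as (diethylcarbamoyl)methyl to 2-(diethylcarbamoyl)ethyl, the change shows no step beyond the scatter. Nothing available offers an explanation for this result.

From the compounds shown here alone, a single step at one position says nothing about how far this result extends, so it remains open whether a longer chain, or a chain ending in a carboxylic acid or a primary amine in place of the diethylcarbamoyl group, would stand apart from compound 3 in this assay. Also open, going by these compounds, is whether changes elsewhere on the shared core, such as replacing the methoxy groups with hydroxyl groups, would give a step beyond the scatter.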